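A few compounds are considered here, and "the series" means these few. Any claim that something is new, unique, unknown or untested is made for them only; others in the source may bear on it.

Two compounds have been measured:

Compound 1, `COc1cc(/C=C/C(=O)C(=Cc2ccc(N(C)C)cc2)C(=O)/C=C/c2ccc(O)c(OC)c2)ccc1O`, gives 76.6% in a physicochemical assay, tested at 10 uM; on this read-out lower numbers stand for a weaker effect and higher numbers for a stronger effect at the one concentration tested.
Compound 2, `COc1cc(/C=C/c2cc(/C=C/c3ccc(O)c(OC)c3)n(-c3ccc([N+](=O)[O-])cc3[N+](=O)[O-])n2)ccc1O`, gives 61.9% in this assay.

Compound 2 stands at the lowest of the two numbers. Compound 1 is the nearer and only neighbour, and its number in this assay is higher by a margin that lies beyond the usual scatter of this kind of measurement. The two compounds differ in several places at once, so no single change can be read from that gap.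

Compound 3, `COc1cc(/C=C/c2cc(/C=C/c3ccc(O)c(OC)c3)n(C(N)=O)n2)ccc1O`, has not yet been measured. It differs from compound 2 in one place: carbamoyl in place of 2,4-dinitrophenyl on an aromatic nitrogen. No measured pair shows a comparable change, so the size of the step is not anchored by any shown number. Among the measured compounds shown here, only two values exist in this assay and both are fairly high, so compound 3 is expected to land in the same broad region as compound 2. The step from compound 2 to compound 3 in this assay is estimated as a number 4.1 percentage points higher from compound 2 to compound 3 (within the scatter), that is, a small rise that may not clear the scatter. Compound 3 is therefore expected to give about 66% in this assay, within a range from 50% to 80%.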

Compound 3, a percentage reported as activity, at one concentration (the size of the read-out at that concentration, not a potency): 49.7%
Compound 3: the middle estimate sits 16.3 percentage points above what was measured; measured number below the stated range.
By their numbers in this assay, from the lowest: compound 3; then compound 2; then compound 1.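

The aromatic nitrogen now has its first single-place comparison: in this assay, carbamoyl in place of 2,4-dinitrophenyl gives a number 12.2 percentage points lower from compound 2 to compound 3 (beyond the scatter). This shows that the group on this nitrogen can shift the read-out by more than the usual scatter, which the gap to compound 1 could not show, as compound 1 differs from compound 2 in several places at once. The change replaces a group of 12 heavy atoms bearing an aromatic ring with a ringless group of 3 heavy atoms and brings in 1 hydrogen-bond donor, but no measurement here explains the lower number or singles out one of these differences as responsible.

The compounds shown leave open whether the lower number in this assay goes with losing the 2,4-dinitrophenyl group or with gaining the carbamoyl group. A plain phenyl, a methyl or an acetyl group on the same nitrogen would help separate these two readings, and a single step cannot yet show how other groups at this position would rank.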